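Widening the aromatic-carbon substituent: compound 3 to compound 4

A few compounds are considered here, and "the series" means these few. Any claim that something is new, unique, unknown or untested is made for them only; others in the source may bear on it.

Measured in an ADME assay for permeability, using PAMPA, at pH 4; a higher number here means that the compound crosses the layer faster, a lower number that the compound crosses the layer more slowly
compound 1 `CCc1c(C)[nH]c2cc(OC)c(Cl)cc2c1=O` gives 96.4 10^-6 cm/s
compound 2 `COc1cc2[nH]c(C)c(C)c(=O)c2cc1Cl` gives 37 10^-6 cm/s
compound 3 `COc1cc2[nH]c(C)c(C(C)C)c(=O)c2cc1Cl` gives 281 10^-6 cm/s

Compound 3 at 281 10^-6 cm/s stands highest of the three, beyond the scatter from both others. Compound 4 `C=C(CCCCC)c1c(C)[nH]c2cc(OC)c(Cl)cc2c1=O` has not yet been measured and differs from compound 3 by a group of 7 heavy atoms (7 carbon; no ring) in place of a group of 3 heavy atoms (3 carbon; no ring), on an aromatic carbon on an aromatic carbon. For the measured compounds named here, three measured steps bear on this position. They are a 2.6-fold lower number from compound 1 to compound 2 (0.42 log units; beyond the scatter) and a 2.9-fold higher number from compound 1 to compound 3 (0.46 log units; beyond the scatter) and a 7.6-fold higher number from compound 2 to compound 3 (0.88 log units; beyond the scatter) and all three are modest. Across these compounds the number rises from methyl through ethyl to isopropyl, and none of the three goes against that. No measured group comes near the size of the entering one, and none holds a double bond outside aromatic rings, so the trend cannot be carried forward with confidence. The expectation leans upward only on the strength of a 7.6-fold higher number from compound 2 to compound 3 (0.88 log units; beyond the scatter) and remains weak. The expected step is a 1.4-fold higher number from compound 3 to compound 4 (0.15 log units; within the scatter) and a wide range is kept around it. In this assay the estimate for compound 4 is 400 10^-6 cm/s with an expected range from 100 10^-6 cm/s to 1200 10^-6 cm/s as a working figure.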

Compound 4, apparent permeability: 768 10^-6 cm/s
Beside the measured number, compound 4's estimate is 1.9-fold (0.28 log units) below it; measured number inside the range.
By their numbers in this assay, from the lowest: compound 2; then compound 1; then compound 3; then compound 4.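

In this assay, for the compounds shown here, the rise at this aromatic carbon continues past isopropyl to the group of 7 heavy atoms with its double bond outside aromatic rings, with a 2.7-fold higher number from compound 3 to compound 4 (0.44 log units; beyond the scatter) as the direct step and an 8.0-fold higher number from compound 1 to compound 4 (0.90 log units; beyond the scatter) and a 21-fold higher number from compound 2 to compound 4 (1.32 log units; beyond the scatter) as the wider comparisons, the last of these being the only large step in the set. The order now runs from methyl through ethyl and isopropyl to this group, none of the four compounds goes against it, and the number has not turned down even at the largest group shown. Nothing available accounts for this rise.

Chain size and the double bond enter together in compound 4, so the compounds shown cannot separate their contributions, and a saturated group of 7 carbon atoms would be the direct comparison. Also open, on these data alone, is whether the rise continues or levels off with a longer chain, and what a ring, an amine or a carboxylic acid at this position would do to the number.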